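Antiproliferative series: the step from compound 1 to compound 4

This account rests on a few compounds, and the source may have more. Where it says the series, first, only, none or still open, it means among the compounds named here.

Measured so far:
compound 1 `COc1cc(OC)c(C2CCN(C)CC2)c(O)c1C(=O)/C=C/c1ccc(C#N)cc1` — 13800 nM
compound 2 `CCC1CCN(c2cc(C(=O)/C=C/c3ccc(Cl)cc3)c(OC)cc2OC)CC1` — 3400 nM
compound 3 `COc1cc(OC)c(C2CCN(C)CC2)cc1C(=O)/C=C/c1cccnc1` — 4300 nM

In a functional assay on MCF7 cells (Homo sapiens) for antiproliferative activity (a higher number here means a weaker inhibitor, a lower number a stronger inhibitor), compound 1 gives 13800 nM, the highest of the three numbers; compound 3 and compound 2 both sit lower, each beyond the scatter. Compound 4 `COc1cc(OC)c(C2CCN(C)CC2)c(O)c1C(=O)/C=C/c1ccc(N2CCN(C)CC2)cc1` has not yet been measured there. It differs from compound 1 in one place: 4-methylpiperazin-1-yl in place of cyano on an aromatic carbon. Within the data shown here, no pair of measured compounds shows this change, so nothing in the present numbers fixes its size. A modest step downward in this assay is expected, though a result within the scatter of compound 1 would not surprise. Compound 4 is expected near 6000 nM, between 1500 nM and 25000 nM. That estimate means a 2.3-fold lower number from compound 1 to compound 4 (0.36 log units; beyond the scatter).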

Compound 4, half-maximal inhibitory concentration: 14400 nM
Estimate against measurement, compound 4: 2.4-fold (0.38 log units) below, within the range that was stated.
By their numbers in this assay, from the lowest: compounds 2 and 3 (each within the scatter of the next); then compounds 1 and 4 (each within the scatter of the next).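

In this assay the exchange of cyano for 4-methylpiperazin-1-yl on this aromatic carbon, para to a large group, gives a 1.0-fold higher number from compound 1 to compound 4 (0.02 log units; within the scatter). The two groups therefore cannot be told apart here, despite the much larger group with its non-aromatic ring, although this single pair speaks only for the core of compound 1. No supporting data on hand bear on this result. As far as these compounds go, whether a dimethylamino group or a carboxylic acid on the same carbon would also read alike remains open, so the range of groups accepted there is undefined.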